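The compounds below may be only part of what the source reports. "The series", "measured", "known", "first", "only" and "open" are said of these compounds alone.

Measured compounds:
compound 1 `COc1ccc(F)cc1S(=O)(=O)Nc1cncc(C(N)=O)c1` — 109 nM
compound 2 `COc1ccc(Cl)cc1S(=O)(=O)Nc1cncc(-c2cccc(C)c2)c1` — "not determined" (no result reported)
compound 3 `COc1ccc(C#N)cc1S(=O)(=O)Nc1cccnc1` — "not determined" (no result reported)

In an assay on isolated protein for inhibition of alkaline phosphatase, tissue-nonspecific isozyme (Homo sapiens) (a lower number here means a stronger inhibitor, a higher number a weaker inhibitor), compound 1 gives 109 nM. Going by the values given here, this is the only number so far: compound 2 and compound 3 carry no result in this assay, so compound 1 stands alone and no step between measured compounds can be drawn.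

Compound 4 `COc1ccc(Br)cc1S(=O)(=O)Nc1cncc(C(N)=O)c1` is the next entry, yet to be measured in this assay. It differs from compound 1 in one place: bromo in place of fluoro on an aromatic carbon. The change sits on an aromatic carbon of a six-membered aromatic ring of carbon only, para to a methoxy group and meta to a large group; the rest of the shared core of compound 1 is kept.

Among the compounds with values here, with no step between measured compounds to lean on, the expectation rests on the single value of compound 1 and on the small size of the change. The step from compound 1 to compound 4 is expected to be small, at most a modest move toward a stronger inhibitor, and it may well stay within the scatter: a 1.6-fold lower number from compound 1 to compound 4 (0.19 log units; within the scatter). Compound 4 is therefore estimated at 70 nM in this assay, with a range from 25 nM to 200 nM.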

Compound 4, half-maximal inhibitory concentration: 121 nM
Compound 4: middle estimate off by 1.7-fold (0.24 log units), on the low side; measured number inside the range.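

In this assay, going by these compounds alone, bromo in place of fluoro on the aromatic carbon para to a methoxy group gives a 1.1-fold higher number from compound 1 to compound 4 (0.05 log units; within the scatter), the only step that can be read so far. Within the data shown here, with the rest of the shared core kept, this position therefore holds either halogen without a change beyond the usual scatter, which the single value of compound 1 could not show. No supporting data bear on why the two halogens give such similar values.

The compounds shown leave open whether an amine, a carboxylic acid or a longer chain on this carbon would stay in the same range. They also leave open how chloro or nitrile would compare here on the core of compound 1; compound 2 and compound 3 carry these groups but offer no number to compare.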